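Amide-to-acid change in a purine series, oral tail flick

The source may hold more compounds than are shown below. What is called first, only, known or untested is meant among the compounds shown, and "the series" means these compounds.

Measured compounds:
- compound 1, `O=C(CN(c1nc(Cl)nc2[nH]cnc12)C1CC1)N[C@@H](CO)C(=O)OCc1ccccc1`: 31.9%
- compound 2, `NC(=O)C[C@H](NC(=O)CN(c1nc(Cl)nc2[nH]cnc12)C1CC1)C(=O)O`: 29.7%

In a functional assay on the whole organism (Tail, strain ICR) with Mus musculus as the target, in the tail flick test, with a stated time of 30 min, at a dose of 25 umol/kg by the oral route (on this read-out higher numbers stand for a stronger effect at the one dose given and lower numbers for a weaker effect), compound 1 gives 31.9%. In this assay compound 2 gives 29.7%. On the numbers shown, compound 2 stands next to compound 1, the two values within the usual scatter of one another, so no order can be read between them. Going by the values given here, the two compounds differ in more than one place, and no single-point step between measured compounds is available here.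

Compound 3, `O=C(O)C[C@H](NC(=O)CN(c1nc(Cl)nc2[nH]cnc12)C1CC1)C(=O)O`, is not yet measured in this assay. Its relation to compound 2 is a single change: hydroxy in place of amino on a carbonyl carbon. Without any measured step to rest on, the expected size of the step from compound 2 to compound 3 is small, in the direction of a slightly weaker effect, but most likely not beyond the scatter; the estimated step is a number 4.7 percentage points lower from compound 2 to compound 3 (within the scatter). For compound 3 in this assay the estimate is 25%, with a range from 10% to 42%.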

Compound 3, a percentage reported as activity, at one dose (the size of the read-out at that dose, not a potency): 19.9%
For compound 3 the middle estimate is 5.1 percentage points above the measured one; measured number inside the range.
By their numbers in this assay, from the lowest: compounds 3, 2 and 1 (each within the scatter of the next, the first and the last beyond it).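

Going by these compounds alone, the carbamoyl to carboxy exchange on the carbonyl carbon provides the first single-place comparison. In this assay, it gives a step that can be read directly (a number 9.8 percentage points lower from compound 2 to compound 3 (within the scatter)). At this one oral dose, the carbamoylmethyl group can therefore give way to carboxymethyl without a change that can be separated from the scatter, so amino and hydroxy cannot be told apart at this place. This one step cannot establish that the place is generally insensitive to change, and no measured property bears on this result.

Still open, going by these compounds, is whether a methyl ester, a primary amine or a longer chain ending in a carboxylic acid at this place would give a step beyond the scatter. Also open, on these data alone, is whether the carbamoyl and carboxy compounds would stay this close at other doses or times, since a read-out at one dose gives the size of the effect there and not a potency.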